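Chloro for fluoro: the step from compound 2 to compound 3

A few compounds are considered here, and "the series" means these few. Any claim that something is new, unique, unknown or untested is made for them only; others in the source may bear on it.

Among the measured compounds shown here, compound 2 `N=C(N)c1ccc(-c2ccc(-c3ccc(F)cc3)s2)cc1` holds the lowest of the two numbers so far in a functional assay on PC-3 cells (Homo sapiens) for inhibition, read by sulforhodamine B assay, with a stated time of 48 h (on this read-out higher numbers stand for weaker inhibition of growth and lower numbers for stronger inhibition of growth), giving 1590 nM; compound 1 `N=C(N)c1ccc(-c2ccc(-c3ccccc3)s2)cc1F` gives 4180 nM, a gap beyond the scatter. Compound 3 `N=C(N)c1ccc(-c2ccc(-c3ccc(Cl)cc3)s2)cc1` differs from compound 2 only by chloro in place of fluoro on an aromatic carbon, para to a large group. For the measured compounds named here, no pair of measured compounds shows this exchange, so no step beyond the scatter is expected in either direction. Compound 3 is expected to give about 1300 nM in this assay, with a range from 500 nM to 3500 nM. The expected step of a 1.2-fold lower number from compound 2 to compound 3 (0.09 log units; within the scatter) stays within the scatter.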

Compound 3, concentration for 50% growth inhibition: 164 nM
The estimate for compound 3 lay 7.9-fold (0.90 log units) above the measured number; the measured number lies below the stated range.
By their numbers in this assay, from the lowest: compound 3; then compound 2; then compound 1.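

In this assay, 4-fluorophenyl to 4-chlorophenyl gives a 9.7-fold lower number from compound 2 to compound 3 (0.99 log units; beyond the scatter) and so shows that this place, para to a large group, is sensitive to the identity of a single halogen atom. The earlier compounds shown here did not show this, as neither carries chloro and they differ in more than one place. No measurement shown here accounts for the size of this step. From the compounds shown here alone, whether bromo, methyl or an amine in the same place would follow chloro or fluoro remains open, and one exchange gives no trend across the halogens.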